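From 3,4-dimethoxyphenyl to 3-nitrophenyl on the shared core

This account rests on a few compounds, and the source may have more. Where it says the series, first, only, none or still open, it means among the compounds named here.

Values measured in a functional assay on SW-620 cells (Homo sapiens) for cytotoxicity, read by sulforhodamine B assay, with a stated time of 48 h; on this read-out higher numbers stand for weaker inhibition and lower numbers for stronger inhibition:
- compound 1 `C[C@H]1CC[C@@H]2[C@@H](OC(=O)[C@]23CC(c2c(Cl)cccc2Cl)=NO3)[C@]2(C)C(=O)C=C[C@@]12O` gives 43000 nM
- compound 2 `C[C@H]1CC[C@@H]2[C@@H](OC(=O)[C@]23CC(c2ccccc2[N+](=O)[O-])=NO3)[C@]2(C)C(=O)C=C[C@@]12O` gives 40000 nM
- compound 3 `COc1ccc(C2=NO[C@]3(C2)C(=O)O[C@@H]2[C@H]3CC[C@H](C)[C@]3(O)C=CC(=O)[C@@]23C)cc1OC` gives 86000 nM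

Compound 3 stands clearly apart from only one of the other two. The step of a 2.2-fold higher number from compound 2 to compound 3 (0.33 log units; beyond the scatter) lies beyond the scatter, while the step of a 2.0-fold higher number from compound 1 to compound 3 (0.30 log units; within the scatter) stays within it.

Compound 4 `C[C@H]1CC[C@@H]2[C@@H](OC(=O)[C@]23CC(c2cccc([N+](=O)[O-])c2)=NO3)[C@]2(C)C(=O)C=C[C@@]12O` has not yet been measured. It differs from compound 3 by a single change (3-nitrophenyl in place of 3,4-dimethoxyphenyl on a carbon with a double bond to nitrogen): 3-nitrophenyl in place of 3,4-dimethoxyphenyl on a carbon with a double bond to nitrogen.

The most relevant measured step is the exchange between 2-nitrophenyl and 3,4-dimethoxyphenyl, a 2.2-fold higher number from compound 2 to compound 3 (0.33 log units; beyond the scatter), read here in reverse. Within the data shown here, no measured compound shows how 3-nitrophenyl compares with 2-nitrophenyl. Among the measured compounds shown here, the step of a 1.1-fold lower number from compound 1 to compound 2 (0.03 log units; within the scatter) shows only that those two groups gave values within the scatter. A step of similar or slightly smaller size towards a lower number is therefore expected, close to the edge of the scatter.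

The expected change is a 1.8-fold lower number from compound 3 to compound 4 (0.25 log units; within the scatter) on this estimate. In this assay the estimate for compound 4 is 48000 nM, with an expected range from 22000 nM to 95000 nM.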

Compound 4, half-maximal inhibitory concentration: 49000 nM
Beside the measured number, compound 4's estimate is 1.0-fold (0.01 log units) below it; measured number inside the range.
By their numbers in this assay, from the lowest: compounds 2, 1, 4 and 3 (each within the scatter of the next, the first and the last beyond it).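

In this assay, among these compounds, 3-nitrophenyl in place of 3,4-dimethoxyphenyl on the carbon with a double bond to nitrogen gives a step that stays within the scatter (a 1.8-fold lower number from compound 3 to compound 4 (0.24 log units; within the scatter)), so the 3,4-dimethoxyphenyl group of compound 3 is not set clearly apart from the nitrophenyl groups as a whole; among the four compounds, only the pair of compound 2 and compound 3 is separated beyond the scatter. The place of the nitro group on the phenyl ring makes no difference that can be read here, since 3-nitrophenyl in place of 2-nitrophenyl also stays within the scatter (a 1.2-fold higher number from compound 2 to compound 4 (0.09 log units; within the scatter)). The same holds for 3-nitrophenyl in place of 2,6-dichlorophenyl (a 1.1-fold higher number from compound 1 to compound 4 (0.06 log units; within the scatter)), which leaves compound 1, compound 2 and compound 4 all within the scatter of one another.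

The compounds shown leave open whether something other than a substituted phenyl on this carbon, such as an amine, a carboxylic acid or a longer alkyl chain, would shift the number further in either direction. Nothing measured here accounts for how close these values lie.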